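Compound 3: hydrogen in place of ethoxy

The source may report more compounds than this note shows. Statements on the series, on what has been measured and on what is new or still open speak of the compounds shown alone.

Going by the values given here, in a functional assay on FaDu cells (Homo sapiens) for cytotoxicity, read by MTT assay, with a stated time of 72 h (on this read-out higher numbers stand for lower toxicity in this test and lower numbers for higher toxicity in this test), compound 1 `CCOc1ccc(NC(=O)C(=O)c2cn(C(C)C)c3ccccc23)cn1` gives 175 nM, the only exact number so far. Compound 2 `COc1ccc(NC(=O)C(=O)c2cn(C(C)C)c3ccc(Cl)cc23)cn1` is recorded as > 10000 nM, which is a limit of the assay and not a number. Compound 3 `CC(C)n1cc(C(=O)C(=O)Nc2cccnc2)c2ccccc21` has hydrogen in place of ethoxy on an aromatic carbon. Among the compounds with values here, no measured pair isolates this change, so the expectation is loose. The expected step of a 4.0-fold higher number from compound 1 to compound 3 (0.60 log units; beyond the scatter) is moderate, beyond the scatter, towards lower toxicity in this assay. The estimate for compound 3 is 700 nM, with an expected range of 120 nM to 5000 nM.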

Compound 3, concentration lethal to 50% of the cells: > 10000 nM
Compound 3 was reported as a limit; the forecaster's own chance of this, stated with the estimate: 12%; middle value at least 14-fold (1.15 log units) away from the limit.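

In this assay, going by these compounds alone, hydrogen in place of ethoxy on the aromatic carbon next to the ring nitrogen gives an at least 57-fold higher number from compound 1 to compound 3 (1.75 log units; beyond the scatter), the first step that isolates one change. The ethoxy group therefore carries the exact value of compound 1 at this position. The value of compound 3 is a limit and not a number, and the step is a minimum because of that limit: the limit of > 10000 nM in this assay, at which 2 of the 3 values shown sit.

Compound 2 differs from compound 1 in two places, so it does not separate either change. As far as these compounds go, whether a longer propoxy chain or an amine at this position keeps the value stays open.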